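Furan-3-yl in place of pyridin-3-yl on compound 1

The source may hold more compounds than are shown below. What is called first, only, known or untested is meant among the compounds shown, and "the series" means these compounds.

In an ADME assay on microsomes from liver (Rattus norvegicus) for metabolic stability, read by LC-MS, using NADPH, with a stated time of 90 min, tested at 1 uM (on this read-out higher numbers stand for a longer-lived compound and lower numbers for a shorter-lived compound), compound 1 (`Fc1ccc(N2CCN(CCCc3c[nH]c4ccc(F)cc34)CC2)c(-c2cccnc2)c1`) gives 0.0967 h and compound 2 (`Fc1ccc2[nH]cc(CCCCN3CCN(c4nsc5ccccc45)CC3)c2c1`) gives 0.0567 h, two values within the scatter of each other. Compound 3 (`Fc1ccc(N2CCN(CCCc3c[nH]c4ccc(F)cc34)CC2)c(-c2ccoc2)c1`) carries furan-3-yl in place of pyridin-3-yl on an aromatic carbon. Among the compounds with values here, no measured pair isolates this change, so the data give no direct guide to its size. In this assay, no step beyond the scatter is expected, with a slight lean towards a shorter-lived compound. The estimated change is a 1.4-fold lower number from compound 1 to compound 3 (0.14 log units; within the scatter). Compound 3 is expected at 0.07 h, with an estimated range of 0.03 h to 0.15 h.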

Compound 3, half-life: 0.172 h
For compound 3 the middle estimate is 2.5-fold (0.39 log units) below the measured one, outside the stated range (above it).
By their numbers in this assay, from the lowest: compounds 2, 1 and 3 (each within the scatter of the next, the first and the last beyond it).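

In this assay, within the data shown here, furan-3-yl in place of pyridin-3-yl on this aromatic carbon, ortho to a large group, gives a 1.8-fold higher number from compound 1 to compound 3 (0.25 log units; within the scatter) as the first step to isolate a change at this position. A five-membered aromatic ring thus stands here in place of a six-membered one without a step beyond the scatter. Nothing measured here accounts for the result. Open, on these data alone, is whether a morpholine or a plain phenyl group at this position would also stay within the scatter of compound 1, and what removing the fluoro group would do.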